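This account rests on a few compounds, and the source may have more. Where it says the series, first, only, none or still open, it means among the compounds named here.

Of the compounds shown here, three have so far been measured in a functional assay on cells (Pituitary gland cell) for antagonist activity at Gonadotropin-releasing hormone receptor (Rattus norvegicus); a lower number here means a stronger inhibitor, a higher number a weaker inhibitor. Compound 1 `CC(=O)OCc1cc(C)cc(-c2c(O)nc3cc(Cl)c([N+](=O)[O-])cc3c2OCCC2CCCCN2)c1` gives 45 nM in this assay, and compound 2 `O=[N+]([O-])c1cc2c(OCCC3CCCCN3)c(-c3ccc4ccccc4c3)c(O)nc2cc1Cl` gives 53 nM in this assay. Among the compounds with values here, the only single-point change among the measured compounds is a 1.2-fold higher number from compound 1 to compound 2 (0.07 log units; within the scatter), a swap of one aryl group for another on an aromatic carbon that leaves the number essentially where it was. Compound 3 `Cc1cc(C)cc(-c2c(O)nc3cc(Cl)c(NC(=O)Nc4cccnc4)cc3c2OCCC2CCCCN2)c1` gives 20 nM in this assay, the lowest of the three numbers; its gaps to compound 1 and to compound 2 both lie beyond the scatter, so compound 3 is the most potent of the three.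

Compound 4 `Cc1cc(C)cc(-c2c(O)nc3cc(Cl)c(NC(=O)Nc4ncccn4)cc3c2OCCC2CCCCN2)c1` differs from compound 3 in one place: pyrimidin-2-yl in place of pyridin-3-yl on an amide-type nitrogen. Within the data shown here, no measured step touches this urea end of the molecule; the one step available concerns a different position and stayed within the scatter, so there is nothing here pointing to a shift in either direction. The expected step is therefore a 1.1-fold higher number from compound 3 to compound 4 (0.04 log units; within the scatter), a change not beyond the scatter. Compound 4 is estimated at 22 nM in this assay, within a range from 8 nM to 60 nM.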

Compound 4, half-maximal inhibitory concentration: 6 nM
The estimate for compound 4 lay 3.7-fold (0.56 log units) above the measured number; the whole stated range lies above it.
By their numbers in this assay, from the lowest: compound 4; then compound 3; then compounds 1 and 2 (each within the scatter of the next).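

Within the data shown here, the urea end of the molecule turns out to be sensitive, which the earlier compounds could not show: in this assay, pyrimidin-2-yl in place of pyridin-3-yl on an amide-type nitrogen gives a step beyond the scatter (a 3.3-fold lower number from compound 3 to compound 4 (0.52 log units; beyond the scatter)), whereas the only earlier step, an aryl swap at another position, stayed within it. The change itself is small, since both groups are six-membered aromatic rings of 6 heavy atoms, and the entering ring differs only in having 2 hetero atoms and 2 hydrogen-bond acceptors where the leaving ring has 1 of each. Nothing available here accounts for the lower number, so the step stands as an observation without an explanation.

This single pair cannot separate the effect of having a second ring nitrogen from the effect of where the ring nitrogens sit, and a comparison with pyridin-2-yl or plain phenyl on the same urea would begin to tell these apart. On these data alone, whether the same swap would give a similar step with a different aryl group on the shared core, such as the naphthalen-2-yl of compound 2, also remains open.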